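Replacing Chloro by a Methylpiperidine on a Sulfonylated Core

A few compounds are considered here, and "the series" means these few. Any claim that something is new, unique, unknown or untested is made for them only; others in the source may bear on it.

Compound 1, `Cc1ccc(S(=O)(=O)n2cnc3c(Cl)ncnc32)cc1`: 22800 nM
Compound 2, `FC(F)(F)c1cccc(CNc2ncnc3[nH]cnc23)c1`: 102000 nM
Compound 3, `Cc1ccc(S(=O)(=O)n2cnc3c(N4CCN(c5ccc(C(F)(F)F)cc5)CC4)ncnc32)cc1`: 4500 nM

In a functional assay on HCT-116 cells (Homo sapiens) for cytotoxicity, read by sulforhodamine B assay, with a stated time of 72 h (on this read-out higher numbers stand for weaker inhibition and lower numbers for stronger inhibition), compound 1 gives 22800 nM, the second highest of the three numbers. Compound 2 gives 102000 nM, a higher number beyond the scatter. Compound 3, which carries a ring amine in place of the chloro, gives 4500 nM, a lower number beyond the scatter.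

Compound 4, `Cc1ccc(S(=O)(=O)n2cnc3c(N4CCC(C)CC4)ncnc32)cc1`, differs from compound 1 by 4-methylpiperidin-1-yl in place of chloro on an aromatic carbon. Within the data shown here, no measured pair shows exactly this change, so the expected step from compound 1 to compound 4 in this assay is taken from compound 3, whose 4500 nM points toward a lower number, though with less confidence for a smaller ring amine. Compound 4 is estimated at 10000 nM, within 3000 nM to 40000 nM, a step of a 2.3-fold lower number from compound 1 to compound 4 (0.36 log units; beyond the scatter).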

Compound 4, half-maximal inhibitory concentration: 14600 nM
For compound 4 the middle estimate is 1.5-fold (0.16 log units) below the measured one; the measured number falls inside the stated range.
By their numbers in this assay, from the lowest: compound 3; then compounds 4 and 1 (each within the scatter of the next); then compound 2.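

In this assay, 4-methylpiperidin-1-yl in place of chloro on this aromatic carbon gives a 1.6-fold lower number from compound 1 to compound 4 (0.19 log units; within the scatter) and that step lies within the scatter. The chloro can therefore give way to this larger ring with no change that the assay can resolve, so the chloro is not needed for a number of this size. No measured property of these compounds bears on this result.

On these data alone, it remains open whether an open-chain amine such as dimethylamine, or a piperidine carrying a carboxylic acid, at this carbon would move the number beyond the scatter from compound 1.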